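A few compounds are considered here, and "the series" means these few. Any claim that something is new, unique, unknown or untested is made for them only; others in the source may bear on it.

Going by the values given here, compound 2 `COc1cc(/C=C/C(=O)C2=C(/C=C/c3ccc(O)c(OC)c3)NC(=S)NC2c2ccc(N(C)C)cc2)ccc1O` is one of two compounds measured so far in a functional assay, with a stated time of 20 min, tested at 50 uM (a lower number here means a weaker effect, a higher number a stronger effect of the compound at the concentration tested), and in this assay compound 2 gives 89.5%, the higher of the two numbers. Compound 1 `COc1cc(/C=C/C(=O)C2=C(/C=C/c3ccc(O)c(OC)c3)NC(=S)NC2c2ccc(C)cc2)ccc1O` differs from it only in the group on the saturated ring carbon, and in this assay compound 1 gives 62%; the step between them is a number 27.5 percentage points higher from compound 1 to compound 2 (beyond the scatter). Compound 3 `COc1cc(/C=C/C(=O)C2=C(/C=C/c3ccc(O)c(OC)c3)NC(=S)NC2c2c(Cl)cccc2Cl)ccc1O` has not yet been measured. The change from compound 2 is 2,6-dichlorophenyl in place of 4-(dimethylamino)phenyl on a saturated ring carbon. Among the compounds with values here, the only measured step touching this saturated ring carbon is a number 27.5 percentage points higher from compound 1 to compound 2 (beyond the scatter), which was modest, and nothing measured shows what the entering group does there. The expected step is therefore a fall, a number 34.5 percentage points lower from compound 2 to compound 3 (beyond the scatter), roughly undoing the earlier gain. Compound 3 is expected to give about 55% in this assay, within a range of 35% to 75%.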

Compound 3, a percentage reported as activity, at one concentration (the size of the read-out at that concentration, not a potency): 50.2%
For compound 3 the middle estimate is 4.8 percentage points above the measured one; measured number inside the range.
By their numbers in this assay, from the lowest: compound 3; then compound 1; then compound 2.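

In this assay, this saturated ring carbon has now carried three different aromatic groups, and swapping in 2,6-dichlorophenyl brings a number 39.3 percentage points lower from compound 2 to compound 3 (beyond the scatter) and also a number 11.8 percentage points lower from compound 1 to compound 3 (beyond the scatter). Compound 3 therefore ranks lowest of the three, so changes here can lower the read-out relative to both earlier compounds, not only raise it as 4-(dimethylamino)phenyl did relative to 4-methylphenyl. The high number of compound 2 thus goes with its own group and is not shared by every substituted phenyl tested here, but nothing available explains this order.

It remains open whether the loss follows from having two chlorines or from where they sit, as a phenyl ring with a single chlorine is not among these compounds. Also open, as far as these compounds go, is how a simple amine or a longer chain would behave at this carbon.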